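The compounds below may be only part of what the source reports. "The series", "measured", "known", "first", "only" and "open" are said of these compounds alone.

Measured so far in a functional assay on MOLT-4 cells (Homo sapiens) for inhibition, read by sulforhodamine B assay, with a stated time of 48 h, tested at 10 uM; on this read-out higher numbers stand for more inhibition at the one concentration tested (going by the name of the read-out) and lower numbers for less inhibition:
compound 1 `c1ccc(-c2cn3ccnc3c(-c3ccc4ncn(C5CCCCC5)c4c3)n2)cc1`: 67.7%
compound 2 `c1cn2cc(-c3ccsc3)nc(-c3ccc4ncn(C5CCCCC5)c4c3)c2n1`: 30%

Among the measured compounds shown here, compound 2 stands lowest of the two numbers in this assay; its nearest neighbour is compound 1, and the single measured step, a number 37.7 percentage points lower from compound 1 to compound 2 (beyond the scatter), lies beyond the scatter, so the swap of phenyl for thiophen-3-yl cost a large share of the inhibition. Compound 3 `Brc1ccc(-c2cn3ccnc3c(-c3ccc4ncn(C5CCCCC5)c4c3)n2)cc1` differs from compound 2 in one place: 4-bromophenyl in place of thiophen-3-yl on an aromatic carbon. This change largely reverses the measured step, since a six-membered ring of carbon only returns at the same position, now carrying bromine. For the measured compounds named here, the only step that bears on it is a number 37.7 percentage points lower from compound 1 to compound 2 (beyond the scatter), which was large; no measured step covers the bromine, so that part is open. The expected change is therefore a rise in this assay, a number 30 percentage points higher from compound 2 to compound 3 (beyond the scatter), back toward the level of compound 1. Compound 3 is estimated at 60%, with a range of 35% to 85%.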

Compound 3, a percentage reported as inhibition, at one concentration (the size of the read-out at that concentration, not a potency): 20.4%
Compound 3: the middle estimate sits 39.6 percentage points above what was measured, and the stated range ends above it.
By their numbers in this assay, from the lowest: compounds 3 and 2 (each within the scatter of the next); then compound 1.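

In this assay, bromo in place of hydrogen on an aromatic carbon gives a number 47.3 percentage points lower from compound 1 to compound 3 (beyond the scatter) and shows that the level of compound 1 does not carry over to every six-membered aromatic ring of carbon only at this position. The change to 4-bromophenyl from thiophen-3-yl gives a number 9.6 percentage points lower from compound 2 to compound 3 (within the scatter) and leaves these two groups unseparated, so among the three compounds only the unsubstituted phenyl of compound 1 holds the higher level. No measurement at hand accounts for either step.

On these data alone, whether the loss belongs to bromine itself or to any group added to the phenyl remains open; 4-fluorophenyl, 4-methoxyphenyl or 4-aminophenyl at this position would separate these cases. As far as these compounds go, how the cyclohexyl group on the shared core contributes also remains open.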